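Shortening the ester-linked chain of compound 1

This account rests on a few compounds, and the source may have more. Where it says the series, first, only, none or still open, it means among the compounds named here.

Compound 1 `CCCC(=O)OCCCCOC(=O)c1ccc(C(=O)Nc2ccc3c(c2)C(C)(C)CCC3(C)C)cc1` sits in the middle of this small set. In a functional assay on K562 cells (Homo sapiens) for inhibition, read by MTT assay, with a stated time of 48 h (on this read-out lower numbers stand for stronger inhibition and higher numbers for weaker inhibition), compound 1 gives 92600 nM, the second highest of the three numbers. Compound 2 `Cc1cc2c(cc1C(=O)c1ccc(C(=O)OCCCOC(=O)c3ccc(C(=O)Nc4ccc5c(c4)C(C)(C)CCC5(C)C)cc3)cc1)C(C)(C)CCC2(C)C` gives 49100 nM, a value within the scatter of that of compound 1, while compound 3 `C=C(c1ccc(C(=O)OCCOC(=O)c2ccc(C(=O)Nc3ccc4c(c3)C(C)(C)CCC4(C)C)cc2)cc1)c1cc2c(cc1C)C(C)(C)CCC2(C)C` gives 504000 nM, a value beyond the scatter on the weaker side.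

Compound 4 `CCCC(=O)OCCCOC(=O)c1ccc(C(=O)Nc2ccc3c(c2)C(C)(C)CCC3(C)C)cc1` is not yet measured. It differs from compound 1 by (propylcarbonyl)oxy in place of ((propylcarbonyl)oxy)methyl on a saturated chain carbon, three bonds along the chain from an oxygen next to a carbonyl group, a plain shortening of the chain. Within the data shown here, no measured pair here carries such a change. A step of this kind is expected to stay within the scatter, with no clear direction. The estimate for compound 4 is 90000 nM, with a range from 40000 nM to 200000 nM, which means an expected step of a 1.0-fold lower number from compound 1 to compound 4 (0.01 log units; within the scatter).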

Compound 4, half-maximal inhibitory concentration: 4570 nM
For compound 4 the middle estimate is 20-fold (1.29 log units) above the measured one; measured number outside the range, below it.
By their numbers in this assay, from the lowest: compound 4; then compounds 2 and 1 (each within the scatter of the next); then compound 3.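

In this assay, the chain length is not a silent feature: (propylcarbonyl)oxy in place of ((propylcarbonyl)oxy)methyl on a saturated chain carbon, three bonds along the chain from an oxygen next to a carbonyl group, gives a 20-fold lower number from compound 1 to compound 4 (1.31 log units; beyond the scatter) with the rest of the molecule unchanged. Among these compounds, no earlier pair could show that this single change moves the number beyond the scatter. No measurement on hand accounts for the step.

On these data alone, whether the shorter 2-((propylcarbonyl)oxy)ethyl chain would continue this trend remains open. So does the outcome of a carboxylic acid or an amine in place of (propylcarbonyl)oxy.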